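The source may report more compounds than this note shows. Statements on the series, on what has been measured and on what is new or still open speak of the compounds shown alone.

Measured compounds:
Compound 1 `CO[C@H]1CC=C2CCN(C)[C@H]2C1` — in an assay on HEK293 cells for antagonist activity at Neuronal acetylcholine receptor; alpha3/beta4 (Rattus norvegicus), read by FLIPR, using a membrane potential dye (a lower number here means a stronger inhibitor, a higher number a weaker inhibitor), compound 1 gives > 300000 nM, a limit of the assay and not a number.
Compound 2 `CN1CC[C@@H]2CC[C@H](O)C[C@@H]21` — in this assay compound 2 gives > 300000 nM, again a limit and not a number.
Compound 3 `O[C@H]1CC[C@H]2CCN[C@H]2C1` — in this assay compound 3 gives > 300000 nM, also a limit and not a number.

All three sit at the limit of > 300000 nM in this assay, at which 3 of the 3 values shown sit. The change from compound 2 to compound 3 is hydrogen in place of methyl on an amine nitrogen in a ring; its size is a step that the two limits leave unreadable from compound 2 to compound 3. The difference between the core of compound 1 and the core of compound 2 is not broken down here.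

Compound 4 `CO[C@H]1CC=C2CCN[C@H]2C1` is not yet measured in this assay. It differs from compound 1 by hydrogen in place of methyl on an amine nitrogen in a ring, the same kind of change as from compound 2 to compound 3, though the earlier place is also described as two ring bonds from the ring atom that bears a fused ring.

For the measured compounds named here, compound 4 is expected to sit at 500000 nM because compound 1 gives > 300000 nM and the one instance of this kind of change seen so far, a step that the two limits leave unreadable from compound 2 to compound 3, stayed at the same limit. The expected step is a step that the limit leaves unreadable from compound 1 to compound 4, most likely reported as a limit again, with a range of 100000 nM to 3000000 nM.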

Compound 4, half-maximal inhibitory concentration: > 300000 nM
Compound 4: only a limit was reported; the forecaster's own chance of this, stated with the estimate: 85%; the middle value is on the limit's open side.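

Compound 4 gives > 300000 nM in this assay, a limit of the assay and not a number. Compound 1 is also reported only as a limit, so no step can be read between compound 1 and compound 4. The compounds shown leave open how hydrogen in place of methyl on an amine nitrogen in a ring affects inhibition, with every result at one limit: the limit of > 300000 nM in this assay, at which 4 of the 4 values shown sit.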